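A few compounds are considered here, and "the series" means these few. Any claim that something is new, unique, unknown or untested is made for them only; others in the source may bear on it.

Two measured compounds anchor this account, compound 1 `NC1CCN(c2c(F)cc3c(=O)c(C(=O)O)cn(C4CC4)c3c2C(F)(F)F)C1` and compound 2 `O=C(O)c1cn(C2CC2)c2c(F)c(N3CCNCC3)c(F)cc2c1=O`, both tested in a functional assay on V79 cells (Cricetulus griseus) for cytotoxicity, read by colony formation; a lower number here means a stronger inhibitor, a higher number a weaker inhibitor. Compound 1 has three entries and gives 300 ug/mL; 300 ug/mL; 300 ug/mL (3 entries). Compound 2 gives 47 ug/mL, the only single number shown, and it is the lower of the two, so compound 2 is the stronger inhibitor. Among the measured compounds shown here, the two differ in more than one place, so no clean step links them.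

Compound 3 `O=C(O)c1cn(C2CC2)c2c(C(F)(F)F)c(N3CCNCC3)c(F)cc2c1=O` has yet to be measured. It departs from compound 2 in one place, with trifluoromethyl in place of fluoro on an aromatic carbon, ortho to a piperazin-1-yl group: trifluoromethyl in place of fluoro on an aromatic carbon. For the measured compounds named here, no measured step isolates this change, so any expectation is loose. Going by the values given here, the only hint is that compound 1, which also carries a trifluoromethyl group, gives 300 ug/mL; 300 ug/mL; 300 ug/mL (3 entries) in this assay. A shift toward weaker inhibition therefore seems more likely than none, and the expected move is a 2.8-fold higher number from compound 2 to compound 3 (0.44 log units; beyond the scatter). For compound 3 the estimated value is 130 ug/mL, with an expected range from 45 ug/mL to 320 ug/mL.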

Compound 3, half-maximal inhibitory concentration: 1650 ug/mL
Beside the measured number, compound 3's estimate is 13-fold (1.10 log units) below it; the measured number lies above the stated range.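

In this assay, among the compounds shown here, the single change of trifluoromethyl in place of fluoro on this aromatic carbon, ortho to a piperazin-1-yl group, appears as a 35-fold higher number from compound 2 to compound 3 (1.55 log units; beyond the scatter) and is classed as large. Compound 1 also carries trifluoromethyl, but it differs from compound 2 in more than one place and so could not tie a shift to this position; with the rest of compound 2 kept the same, this step shows that the change alone moves the number strongly toward weaker inhibition. The results shown offer no measurement that explains why this replacement has so large an effect.

For the compounds shown here, it remains open whether the same replacement would produce a similar step with another group in place of the piperazin-1-yl group, since this pair gives only one reading of the change. From the compounds shown here alone, it is also open how a methyl group, a chlorine atom or a methoxy group on this aromatic carbon would compare with fluoro and trifluoromethyl, and so whether the number climbs gradually across such groups or changes abruptly with trifluoromethyl alone.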